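Methyl Ester to Dimethylamide in an Inactive Pair

The source may report more compounds than this note shows. Statements on the series, on what has been measured and on what is new or still open speak of the compounds shown alone.

Of the compounds shown here, three have been measured in an assay on isolated protein for inhibition of MAP kinase-interacting serine/threonine-protein kinase 1 (Homo sapiens), read by HTRF, in the presence of a further agent that is not named here; on this read-out lower numbers stand for stronger inhibition and higher numbers for weaker inhibition. Compound 1 `N#Cc1ccc(Nc2ncnc3ccc(-c4ccc(C(=O)N5CCNCC5)cc4)nc23)cc1` carries a different side arm on the shared core, and in this assay compound 1 gives 0.15 nM. Compound 2 `Cc1c(C(=O)N2CCOCC2)oc2ccc(Nc3ncnc4ccc(Cl)nc34)cc12` bears a morpholine amide on its bicyclic fragment. In this assay compound 2 reaches only the limit > 10000 nM, not a number. Compound 3 `COC(=O)c1oc2ccc(Nc3ncnc4ccc(Cl)nc34)cc2c1C` is the methyl ester counterpart. In this assay compound 3 also reaches only the limit > 10000 nM, so no number is known for it. The step that the two limits leave unreadable from compound 2 to compound 3 is thus unreadable, since both ends sit at the limit of > 10000 nM in this assay, at which 2 of the 3 values shown sit.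

Compound 4 `Cc1c(C(=O)N(C)C)oc2ccc(Nc3ncnc4ccc(Cl)nc34)cc12` differs from compound 3 by one change: dimethylamino in place of methoxy on a carbonyl carbon. Within the data shown here, the dimethylamide so formed is a close relative of both the morpholine amide of compound 2 and the methyl ester of compound 3, and no measured step shows any readable movement for changes of this kind. The step from compound 3 to compound 4 is therefore expected to be a step that the limit leaves unreadable from compound 3 to compound 4, that is, nothing beyond the scatter. Compound 4 is expected to give about 20000 nM, within 8000 nM to 100000 nM, most probably again as a limit rather than a number.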

Compound 4, half-maximal inhibitory concentration: > 10000 nM
Compound 4: a limit, no number (the forecaster's own chance of this, stated with the estimate: 85%); the middle value lies beyond the limit too.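

No step can be read among compound 2, compound 3 and compound 4, because each stops at a limit rather than a number: the limit of > 10000 nM in this assay, at which 3 of the 4 values shown sit. In this assay, on these data alone, their true strengths stay open, and so does whether methoxy, dimethylamino or morpholin-4-yl on the carbonyl carbon makes any difference.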